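This account rests on a few compounds, and the source may have more. Where it says the series, first, only, none or still open, it means among the compounds named here.

Three compounds share one core and differ only in the group on the benzene ring attached to the carbonyl. Compound 1 `O=C(/C=C/c1ccc2c(c1)B(O)OC2)c1ccccc1` carries no substituent there; in a functional assay on MDA-MB-231 cells (Homo sapiens) for cytotoxicity, read by MTT assay, with a stated time of 48 h (on this read-out lower numbers stand for stronger inhibition and higher numbers for weaker inhibition), compound 1 gives 2300 nM. Compound 2 `O=C(/C=C/c1ccc2c(c1)B(O)OC2)c1ccc(F)cc1` carries fluoro, and compound 2 gives 1600 nM. Compound 3 `O=C(/C=C/c1ccc2c(c1)B(O)OC2)c1ccc(Br)cc1` carries bromo, and compound 3 gives 9500 nM, the highest number of the three, meaning the weakest inhibition. The two steps leading to it are a 4.1-fold higher number from compound 1 to compound 3 (0.62 log units; beyond the scatter) and a 5.9-fold higher number from compound 2 to compound 3 (0.77 log units; beyond the scatter), while a 1.4-fold lower number from compound 1 to compound 2 (0.16 log units; within the scatter).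

Compound 4 `CSc1ccc(C(=O)/C=C/c2ccc3c(c2)B(O)OC3)cc1` takes the next step at the same position: methylsulfanyl in place of bromo on an aromatic carbon. The measured steps show that exchanging the group at this position can move the number beyond the scatter, but none of them involves methylsulfanyl, so the direction is uncertain. Because compound 3 gives 9500 nM and bromo gave the highest number, compound 4 is expected to land near it, with a step of a 1.9-fold lower number from compound 3 to compound 4 (0.28 log units; within the scatter) in this assay, giving an estimate of 5000 nM with a range from 1500 nM to 16000 nM.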

Compound 4, half-maximal inhibitory concentration: 9800 nM
Compound 4: the middle estimate sits 2.0-fold (0.29 log units) below what was measured, and the stated range covers the measured number.
By their numbers in this assay, from the lowest: compounds 2 and 1 (each within the scatter of the next); then compounds 3 and 4 (each within the scatter of the next).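

Exchanging bromo for methylsulfanyl makes no readable difference in this assay, with a 1.0-fold higher number from compound 3 to compound 4 (0.01 log units; within the scatter), so two different groups at this position give matching numbers. For the compounds shown here, the steps from the other two compounds, a 4.3-fold higher number from compound 1 to compound 4 (0.63 log units; beyond the scatter) and a 6.1-fold higher number from compound 2 to compound 4 (0.79 log units; beyond the scatter), are both beyond the scatter, which means bromo is no longer the only group here that gives a clearly higher number than hydrogen and fluoro: the four compounds now fall into two pairs, with compounds 1 and 2 on the lower side and compounds 3 and 4 on the higher side. Nothing available explains why bromo and methylsulfanyl behave alike.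

The compounds shown leave open where an amine, a carboxylic acid or a longer chain such as ethylsulfanyl would fall relative to these two pairs. They also leave open whether the same split would appear in a different cell line.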